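This account rests on a few compounds, and the source may have more. Where it says the series, first, only, none or still open, it means among the compounds named here.

Measured in a functional assay on PC-3 cells (Homo sapiens) for cytotoxicity, read by sulforhodamine B assay, with a stated time of 5 days; on this read-out higher numbers stand for weaker inhibition and lower numbers for stronger inhibition:
- compound 1 `O=C(CCCCCCCCCCCc1ccccc1)CC(=O)N[C@H]1CCOC1=O`: 4000 nM
- compound 2 `O=C(CCCCCCCCCCc1ccccc1)N[C@H]1CCOC1=O`: 66000 nM

For the measured compounds named here, only two compounds have been measured so far, and they differ in more than one place. Their values therefore show a gap but do not explain it. Compound 2, at 66000 nM, has the higher number of the two in this assay, which makes it the weaker inhibitor, and the gap to compound 1 lies beyond the scatter.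

The next compound is compound 3 `O=C(CCCCCCCCCc1ccccc1)N[C@H]1CCOC1=O`. Its change from compound 2 is small: phenyl in place of benzyl on a saturated chain carbon, nine bonds along the chain from a carbonyl carbon.

Going by the values given here, no measured pair shows what this kind of change does, so the closest guide is compound 2 itself, at 66000 nM. The expected outcome is no step beyond the scatter, with a slight lean towards weaker inhibition, and the estimated step is a 1.2-fold higher number from compound 2 to compound 3 (0.08 log units; within the scatter). For compound 3 the estimated value is 80000 nM, with an expected range from 35000 nM to 180000 nM.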

Compound 3, half-maximal inhibitory concentration: 75000 nM
Beside the measured number, compound 3's estimate is 1.1-fold (0.03 log units) above it; low and high end bracket the measured number.
By their numbers in this assay, from the lowest: compound 1; then compounds 2 and 3 (each within the scatter of the next).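

In this assay, putting phenyl in place of benzyl on this saturated chain carbon, nine bonds along the chain from a carbonyl carbon, gives a 1.1-fold higher number from compound 2 to compound 3 (0.06 log units; within the scatter). For the compounds shown here, this is the first measured pair that differs in only one place, and it shows that this small change at the phenyl end of the chain cannot be told apart from the ordinary variation between repeated measurements. Nothing measured separately on these compounds bears on this result.

This single step does not show whether the read-out would stay as flat with a much longer chain, or with an amine or a carboxylic acid in place of the phenyl group at the same chain end. The gap between compound 1 and compound 2 also remains unexplained, since those two compounds differ in more than one place and the step to compound 3 does not separate those differences.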